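The source may hold more compounds than are shown below. What is called first, only, known or untested is meant among the compounds shown, and "the series" means these compounds.

In a functional assay on RAW264.7 cells (Mus musculus) for inhibition, read by MTT assay (a lower number here means a stronger inhibitor, a higher number a weaker inhibitor), compound 1 `Oc1ccc(/C=C/CC[C@H](O)CCc2ccc(O)c(O)c2)cc1` gives 42000 nM, compound 2 `Oc1ccc(/C=C/CC[C@@H](O)CCc2ccc(O)c(O)c2)cc1` gives 20600 nM and compound 3 `CC(=O)O[C@@H](CC/C=C/c1ccc(O)cc1)CCc1ccc(O)c(O)c1` gives 6540 nM, the lowest of the three numbers. Compound 4 `CC(=O)O[C@H](CC/C=C/c1ccc(O)cc1)CCc1ccc(O)c(O)c1` is the configurational partner of compound 3: the two compounds have the same atoms and bonds and differ only in configuration as drawn: 1 of 2 stereo elements differ; a stereocentre at a saturated chain carbon is drawn S in compound 3 and R in compound 4. Within the data shown here, the closest precedent is the same S-to-R change without the acetyl, a 2.0-fold lower number from compound 1 to compound 2 (0.31 log units; beyond the scatter), which is due to the fact that compounds 1 and 2 differ only in the configuration as drawn. Going by these compounds, the acetyl itself accounts for a 6.4-fold lower number from compound 1 to compound 3 (0.81 log units; beyond the scatter), and whether the configurational step carries over with the acetyl in place is untested. A modest step to a lower number is therefore expected in this assay, of similar size or slightly smaller. The expected step is a 1.6-fold lower number from compound 3 to compound 4 (0.21 log units; within the scatter). Compound 4 is estimated at 4000 nM, with an expected range of 1800 nM to 9000 nM.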

Compound 4, half-maximal inhibitory concentration: 15600 nM
Estimate against measurement, compound 4: 3.9-fold (0.59 log units) below; measured number outside the range, above it.
By their numbers in this assay, from the lowest: compound 3; then compounds 4 and 2 (each within the scatter of the next); then compound 1.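

In this assay, configuration at this saturated chain carbon and the acetyl do not act independently. Without the acetyl the S-to-R change gives a 2.0-fold lower number from compound 1 to compound 2 (0.31 log units; beyond the scatter), whereas with it the direction reverses, with a 2.4-fold higher number from compound 3 to compound 4 (0.38 log units; beyond the scatter). On the compounds drawn R, acetyl in place of hydrogen gives only a 1.3-fold lower number from compound 2 to compound 4 (0.12 log units; within the scatter), so its effect depends on configuration: the same change on two cores in this assay, a 6.4-fold lower number (0.81 log units; beyond the scatter) from compound 1 to compound 3 and a 1.3-fold lower number (0.12 log units; within the scatter) from compound 2 to compound 4, 4.9-fold (0.69 log units) apart, beyond the scatter of two such steps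

Going by these compounds, whether this dependence on configuration extends to other groups on this oxygen, such as a benzoyl group or a longer acyl chain, remains open.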